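Benzimidazole-linked biphenyl acids: saturated ring at the imidazole

A few compounds are considered here, and "the series" means these few. Any claim that something is new, unique, unknown or untested is made for them only; others in the source may bear on it.

Measured compounds:
- compound 1, `O=C(O)c1ccccc1-c1ccc(CCc2ncc(CC3CCC3)[nH]2)cc1`: 588 nM
- compound 2, `CCCCc1cnc(CCc2ccc(-c3ccccc3C(=O)O)cc2)[nH]1`: 2710 nM
- compound 3, `O=C(O)c1ccccc1-c1ccc(CCc2ncc(Cc3cccc(F)c3)[nH]2)cc1`: 159 nM

In an in vitro functional assay on cells for agonist activity at Bombesin receptor subtype-3 (Homo sapiens), read by luminescence and calcium flux (a lower number here means that less compound is needed, a higher number that more compound is needed for the effect), compound 3 gives the lowest of the three numbers, with compound 1 the nearest and compound 2 the furthest. The steps that reach compound 3 both replace a saturated group with the 3-fluorophenyl: a 3.7-fold lower number from compound 1 to compound 3 (0.57 log units; beyond the scatter) and a 17-fold lower number from compound 2 to compound 3 (1.23 log units; beyond the scatter). Between the two saturated groups themselves, a 4.6-fold higher number from compound 1 to compound 2 (0.66 log units; beyond the scatter) shows that the cyclobutyl is preferred over the propyl on that chain carbon.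

Compound 4, `O=C(O)c1ccccc1-c1ccc(CCc2ncc(C3CCCCC3)[nH]2)cc1`, has not yet been measured. It differs from compound 3 as follows: cyclohexyl in place of 3-fluorobenzyl on an aromatic carbon. The change runs against the direction of the two steps into compound 3, removing the aromatic ring and putting a saturated ring directly on the aromatic carbon, without the saturated chain carbon that compounds 1, 2 and 3 share. Among the measured compounds shown here, compound 1 is the closest measured reference for a saturated ring at this position, so a higher number than compound 3 is expected in this assay, of a size near the reverse of a 3.7-fold lower number from compound 1 to compound 3 (0.57 log units; beyond the scatter) and possibly larger, since the linking carbon is also lost and no measured step covers that. Compound 4 is therefore expected at 800 nM, within 250 nM to 2600 nM, which corresponds to an expected step of a 5.0-fold higher number from compound 3 to compound 4 (0.70 log units; beyond the scatter).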

Compound 4, half-maximal effective concentration: 375 nM
Beside the measured number, compound 4's estimate is 2.1-fold (0.33 log units) above it; low and high end bracket the measured number.
By their numbers in this assay, from the lowest: compound 3; then compounds 4 and 1 (each within the scatter of the next); then compound 2.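

In this assay, a saturated ring set directly on the aromatic carbon performs on a par with the cyclobutylmethyl group, so the saturated chain carbon shared by compounds 1, 2 and 3 is not needed for a number in this range, at least with the larger cyclohexyl ring (a 1.6-fold lower number from compound 1 to compound 4 (0.20 log units; within the scatter)). The 3-fluorobenzyl group of compound 3 keeps the lowest number of the four, but its margin over cyclohexyl is modest (a 2.4-fold higher number from compound 3 to compound 4 (0.37 log units; beyond the scatter)), so an aromatic ring is not essential at this position. The butyl group of compound 2 stays clearly behind (a 7.2-fold lower number from compound 2 to compound 4 (0.86 log units; beyond the scatter)), and all three ring-bearing compounds give lower numbers than this open chain. Nothing given here accounts for these differences.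

The compounds shown leave open how ring size and the chain carbon contribute separately, a question that cyclohexylmethyl at this carbon would address. They also leave open whether the margin of compound 3 comes from its fluorine or from the aromatic ring itself, which plain benzyl would help to separate.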